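A few compounds are considered here, and "the series" means these few. Any claim that something is new, unique, unknown or untested is made for them only; others in the source may bear on it.

Working notes on the hydroxylated butenolide series.

Of the compounds shown here, two carry measured numbers so far. Compound 1 `O=C1OC(c2cc(O)cc(O)c2)C(c2ccc(O)cc2)=C1O` was tested in a functional assay on PC-3 cells (Homo sapiens) for antiproliferative activity, read by MTT assay, with a stated time of 72 h, tested at 10 uM (a higher number here means more inhibition at the concentration tested (going by the name of the read-out), a lower number less inhibition), and in that setting compound 1 gives 39%. Compound 2 `O=C1OC(c2ccc(O)c(O)c2)C(c2ccc(O)cc2)=C1O` was run in this assay as well, and compound 2 gives 20%. Among the compounds with values here, compound 2 therefore stands lowest of the two numbers available; the only neighbour is compound 1, whose value sits higher by a margin beyond the usual scatter of this read-out.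

The next compound, compound 3 `O=C1OC(c2ccc(O)cc2)C(c2ccc(O)cc2)=C1O`, is not yet measured. Relative to compound 2 the change is hydrogen in place of hydroxy on an aromatic carbon, the place being ortho to a hydroxy group and meta to a large group. Within the data shown here, no measured pair covers exactly this change, so only a loose expectation is possible. Compound 3 is expected to move upward from compound 2 by about a number 10 percentage points higher from compound 2 to compound 3 (within the scatter), a step of roughly the size of the scatter, given that compound 1, which carries a different hydroxy pattern on the same ring, gives 39%. Compound 3 is estimated at 30%, with a range from 10% to 50%.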

Compound 3, a percentage reported as inhibition, at one concentration (the size of the read-out at that concentration, not a potency): 0%
The estimate for compound 3 lay 30 percentage points above the measured number; measured number below the stated range.
By their numbers in this assay, from the lowest: compound 3; then compound 2; then compound 1.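

In this assay, within the data shown here, hydrogen in place of hydroxy on the aromatic carbon ortho to a hydroxy group and meta to a large group gives a number 20 percentage points lower from compound 2 to compound 3 (beyond the scatter) as the first step that can be read at a single place. This position is therefore not indifferent to the change, as the read-out falls with the loss of this one hydroxy group, and compound 3 at 0% is left with no inhibition at the concentration tested. Nothing available here accounts for the size of this step.

The compounds shown leave open whether a hydroxy group is specifically needed at this position or whether another group, such as a methoxy group, an amine or a fluorine atom, would give a similar number there. They also leave open whether the same exchange of hydrogen for hydroxy at the other hydroxy groups of the shared core gives a step of similar size, and whether a carboxylic acid or a longer chain would be accepted at any of those places.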